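Cinnamate esters: a bromophenyl replacing dimethoxyphenyl

This account rests on a few compounds, and the source may have more. Where it says the series, first, only, none or still open, it means among the compounds named here.

The two measured compounds share a cinnamate ester core. Compound 1, `COc1ccccc1/C=C/C(=O)OC/C=C/c1cc(OC)c(OC)cc1OC`, gives 100% in a functional assay on the whole organism (strain Kunming) with Mus musculus as the target, with a stated time of 0.5 h, at a dose of 300 mg/kg by the intraperitoneal route; a lower number here means a stronger effect, a higher number a weaker effect of the compound at the dose given. Among the measured compounds shown here, compound 2, `COc1cc(OC)c(OC)cc1/C=C/COC(=O)/C=C/c1ccc(OC)c(OC)c1`, gives 75% in this assay, and so stands lowest of the two numbers, with compound 1 as its only neighbour. For the measured compounds named here, the single measured step, a number 25 percentage points lower from compound 1 to compound 2 (beyond the scatter), turned on the aryl group attached to the double-bonded chain carbon bound to a double-bonded chain carbon, the same place that changes next.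

Compound 3, `COc1cc(OC)c(OC)cc1/C=C/COC(=O)/C=C/c1ccc(Br)cc1`, differs from compound 2 as follows: 4-bromophenyl in place of 3,4-dimethoxyphenyl on a double-bonded chain carbon bound to a double-bonded chain carbon. Going by the values given here, no measured step exchanges an aryl group for a halogenated one, so the only guidance is that a change at this place shifted this assay by a modest amount in the step from compound 1 to compound 2. Compound 3 is therefore expected to remain near compound 2, with a step of a number 5 percentage points higher from compound 2 to compound 3 (within the scatter). The estimate for compound 3 in this assay is 80%, within a range from 45% to 100%.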

Compound 3, a percentage reported as activity, at one dose (the size of the read-out at that dose, not a potency): 75%
Compound 3: middle estimate off by 5 percentage points, on the high side; measured number inside the range.
By their numbers in this assay, from the lowest: compounds 2 and 3 (each within the scatter of the next); then compound 1.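

In this assay, the exchange of 3,4-dimethoxyphenyl for 4-bromophenyl on a double-bonded chain carbon bound to a double-bonded chain carbon gives no change at the digits printed from compound 2 to compound 3 (within the scatter), so this place tolerates a group with 0 hydrogen-bond acceptors in place of one with 2 hydrogen-bond acceptors without a change in the read-out beyond the scatter. The other new step is a number 25 percentage points lower from compound 1 to compound 3 (beyond the scatter), the same size as a number 25 percentage points lower from compound 1 to compound 2 (beyond the scatter), which sets the 2-methoxyphenyl of compound 1 apart from both of the other aryl groups, while these two cannot be told apart in this read-out. Nothing available bears on the reason for these numbers.

The compounds shown leave open whether a plain phenyl, or an aromatic ring carrying an amine or a carboxylic acid, would give a number in the same range at this place, and so whether the read-out at this place can go lower at all. They also leave open how the read-out would respond to a change elsewhere in the shared core, which stays the same in all three compounds.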